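The compounds below may be only part of what the source reports. "The series", "measured", "known", "first", "only" and "open" are said of these compounds alone.

Measured compounds:
Compound 1, `CN1CCN(c2nc(-c3ccc(Cl)c(Cl)c3)nc3[nH]cnc23)CC1`. In an assay on cells for displacement of a labelled ligand from adenosine receptor A1 (Homo sapiens), read by scintillation counting and radioligand binding, with a stated time of 60 min, tested at 10 uM (a lower number here means less inhibition, a higher number more inhibition at the concentration tested (going by the name of the read-out)), compound 1 gives > 80%, which is a limit of the assay rather than a number.
Compound 2, `Clc1ccc(-c2nc(N3CCCCC3)c3nc[nH]c3n2)cc1Cl`. In this assay compound 2 gives 24.1%.

For the measured compounds named here, compound 2 therefore stands as the only plain number among the two values shown. The other value is a limit, (the limit of > 80% in this assay, at which 1 of the 2 values shown sits). Going by the values given here, the single measured step, a number at least 55.9 percentage points lower from compound 1 to compound 2 (beyond the scatter), concerns a different part of the structure and does not touch the ring that is altered next.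

Compound 3, `Clc1ccc(-c2nc(N3CCCCC3)c3nc[nH]c3n2)cc1`, differs from compound 2 by hydrogen in place of chloro on an aromatic carbon. Among the compounds with values here, no measured step involves this position, so there is no direct guide to the size or direction of the step. In the absence of such a guide, compound 3 is expected to remain close to compound 2, with an estimated step of a number 4.1 percentage points lower from compound 2 to compound 3 (within the scatter), within the scatter. The estimate for compound 3 in this assay is 20%, expected to fall between 5% and 40%.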

Compound 3, a percentage reported as inhibition, at one concentration (the size of the read-out at that concentration, not a potency): > 80%
Compound 3: no number, only a limit; the forecaster's own chance of this, stated with the estimate: 5%; middle value at least 60 percentage points away from the limit.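

Taking away one chloro group, with piperidin-1-yl left in place, moves the result in this assay by a large amount: a number at least 55.9 percentage points higher from compound 2 to compound 3 (beyond the scatter). For the compounds shown here, the earlier step showed only that the group on the core matters, whereas this one shows that a single position on the chlorinated six-membered aromatic ring, ortho to the remaining chloro group, matters too, and that the second chloro group is not needed for a high reading. As far as these compounds go, the result for compound 3 is a limit and not a number, so the true size of the step stays unknown, and this reading sits at the same ceiling as another compound: the limit of > 80% in this assay, at which 2 of the 3 values shown sit.

From the compounds shown here alone, whether fluoro, methyl or an amine at this position would also keep the reading high remains open. So does the effect of replacing the remaining chloro group, and whether the same change would act alike with 4-methylpiperazin-1-yl on the core.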